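The source may hold more compounds than are shown below. What is called first, only, known or untested is meant among the compounds shown, and "the series" means these compounds.

Three compounds of the series carry a measurement in a functional assay on NCI-H292 cells (Homo sapiens) for antiproliferative activity; a higher number here means a weaker inhibitor, a lower number a stronger inhibitor. Compound 1, `COc1ccc(/C=C2\NC(=O)N(c3ccc(Cl)cc3)C2=O)cc1`, gives 32100 nM in this assay. Compound 2, `COc1ccc(N2C(=O)N/C(=C\c3ccc(O)cc3)C2=O)cc1`, returns only a limit in this assay, > 200000 nM. Compound 3, `O=C(O)c1ccc(N2C(=O)N/C(=C\c3ccc(O)cc3)C2=O)cc1`, likewise returns only a limit in this assay, > 200000 nM. For the measured compounds named here, the single one-place step, a step that the two limits leave unreadable from compound 2 to compound 3, therefore cannot be read, and compound 3 stands at the limit of the assay with no number of its own; the only evidence on the measured steps is the limit of > 200000 nM in this assay, at which 2 of the 3 values shown sit.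

Compound 4, `O=C(NCc1ccccc1)c1ccc(N2C(=O)N/C(=C\c3ccc(O)cc3)C2=O)cc1`, differs from compound 3 by benzylamino in place of hydroxy on a carbonyl carbon. Going by the values given here, no measured step touches a carbonyl carbon, and the one measured step is unreadable, so no size can be carried over from it. The expectation for compound 4 rests on the limit for compound 3 alone: the step of an at least 2.0-fold lower number from compound 3 to compound 4 (0.30 log units; that floor lies within the scatter) is estimated without a direction that any measured step supports, and the chance that compound 4 again returns only a limit in this assay is taken as even. Compound 4 is accordingly estimated at 100000 nM, with a range from 20000 nM to 200000 nM.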

Compound 4, half-maximal inhibitory concentration: > 200000 nM
Compound 4 was reported as a limit (the forecaster's own chance of this, stated with the estimate: 50%); middle value at least 2.0-fold (0.30 log units) from the limit.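

Compound 4 also returns only a limit in this assay, > 200000 nM. The steps to it from compound 2 and from compound 3 therefore cannot be read, and no new step follows: the limit of > 200000 nM in this assay, at which 3 of the 4 values shown sit.

Still open, as far as these compounds go, is whether any group on the aromatic carbon changes the read-out in this assay, with only compound 1 giving a number, 32100 nM.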